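The source may hold more compounds than are shown below. What is called first, only, known or untested is meant among the compounds shown, and "the series" means these compounds.

Compound 1 `COc1ccc(-n2c(C)c(N(C)C)c(=O)n(C)c2=O)cc1` gives 1.96 in a physicochemical assay for lipophilicity; a higher number here means a more lipophilic compound, a lower number a more polar compound. Compound 2 `C=CCN(CC=C)c1c(C)n(-c2ccccc2)c(=O)n(C)c1=O` gives 2.59 in this assay. Compound 3 `Cc1c(N(C)C)c(=O)n(CCO)c(=O)n1-c1ccccc1` gives 1.12 in this assay.

Among these three, compound 3 shows the lowest number. Compound 1 stands nearest to it, higher by a gap beyond the usual scatter, and compound 2 stands furthest, higher again by a gap well beyond the scatter. Among the measured compounds shown here, no pair of these measured compounds differs in only one place, so no single step can be read off directly.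

Compound 4 `Cc1c(N(C)C)c(=O)n(C)c(=O)n1-c1ccccc1` has not yet been measured in this assay. It differs from compound 3 in one place: hydrogen in place of hydroxymethyl on a saturated chain carbon bound to an aromatic nitrogen. Both compound 1 and compound 2, which carry no hydroxymethyl, give higher numbers than compound 3 in this assay. On that basis the change from compound 3 to compound 4 is expected to raise the number by a clear step beyond the scatter, a number 0.88 log units higher from compound 3 to compound 4 (beyond the scatter). Compound 4 is therefore estimated at 2 in this assay, with a likely range from 1.6 to 2.4.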

Compound 4, partition coefficient: 1.19
Compound 4: middle estimate off by 0.81 log units, on the high side; measured number outside the range, below it.
By their numbers in this assay, from the lowest: compounds 3 and 4 (each within the scatter of the next); then compound 1; then compound 2.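

On a saturated chain carbon bound to an aromatic nitrogen, the change from 2-hydroxyethyl to methyl gives a number 0.07 log units higher from compound 3 to compound 4 (within the scatter) in this assay and so leaves no readable difference at this position. The changes on aromatic carbons read differently: dimethylamino in place of diallylamino gives a number 1.40 log units lower from compound 2 to compound 4 (beyond the scatter) and hydrogen in place of methoxy gives a number 0.77 log units lower from compound 1 to compound 4 (beyond the scatter) in this assay as well. Read through compound 4, the higher numbers of compound 1 and compound 2 therefore go with those two aromatic-carbon changes and not with the chain.

As far as these compounds go, whether a longer chain, an amine or a carboxylic acid at this chain position would also stay within the scatter of methyl remains open. No measurement shown here gives a reason for the size of any of these steps.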